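Phenol to aminopropyl ether: notes toward compound 4

The source may report more compounds than this note shows. Statements on the series, on what has been measured and on what is new or still open speak of the compounds shown alone.

Measured so far:
compound 1 `CNCCCOc1c(Br)cc(-c2c[nH]c(=O)c(Cc3ccc(OC)c(Br)c3)n2)cc1Br` gives 42800 nM in a functional assay on B16-F10 cells (Mus musculus) for inhibition, read by MTT assay, with a stated time of 24 h; a lower number here means a stronger inhibitor, a higher number a weaker inhibitor
compound 2 `COc1ccc(Cc2nc(-c3cc(Br)c(O)c(Br)c3)c[nH]c2=O)cc1Br` gives "not determined" (no result reported) in this assay
compound 3 `COc1ccc(Cc2nc(-c3cc(Br)c(O)c(Br)c3)cnc2Cl)cc1Br` gives "not determined" (no result reported) in this assay

Compound 2 stands without a number: in this assay compound 2 has no reported result, and the same holds for compound 3, so there is no measured value against which compound 2 can be placed. For the measured compounds named here, the only number comes from compound 1, which in this assay gives 42800 nM.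

The next compound is compound 4 `COc1ccc(Cc2nc(-c3cc(Br)c(OCCCN(C)C)c(Br)c3)c[nH]c2=O)cc1Br`. Relative to compound 2 the change is 3-(dimethylamino)propyl in place of hydrogen on an oxygen on an aromatic ring. Going by the values given here, no pair of measured compounds differing in one place is available, so the size of the step in this assay from compound 2 to compound 4 cannot be taken from the data, and no direction can be set for it beyond the scatter.

The closest measured point is compound 1, which carries a related chain on the same oxygen of the shared core and in this assay gives 42800 nM. On that basis compound 4 is expected to land near the weak end, with an estimate of 40000 nM and a range from 15000 nM to 110000 nM in this assay.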

Compound 4, half-maximal inhibitory concentration: 29600 nM
The estimate for compound 4 lay 1.4-fold (0.13 log units) above the measured number; measured number inside the range.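

In this assay, methyl in place of hydrogen on the amine nitrogen of the chain on this oxygen gives a 1.4-fold lower number from compound 1 to compound 4 (0.16 log units; within the scatter) and so leaves the two chain ends indistinguishable at this read-out. For the compounds shown here, this is the first pair that differs in one place, and it shows that a single methyl at the end of the chain does not separate the compounds, with compound 4 at 29600 nM remaining in the same range as its partner. No measurement available here speaks to why the two numbers stand so close.

As far as these compounds go, compound 2 carries no single number in this assay, so the step from hydroxy to 3-(dimethylamino)propoxy cannot be read, and what the chain as a whole contributes on this oxygen stays unknown. Also open, from the compounds shown here alone, is whether anything at this position moves the number beyond the scatter, for example a primary amine or a carboxylic acid at the chain end, a longer chain between the oxygen and the amine, or a simple methyl ether in place of the chain.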